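Removing the methylpiperazine from a phenyl amidine: two core series

A few compounds are considered here, and "the series" means these few. Any claim that something is new, unique, unknown or untested is made for them only; others in the source may bear on it.

Compound 1 `COc1cc(Nc2nc(C(=N)Nc3ccc(N4CCN(C)CC4)cc3)cc3c(-c4ccccc4)n[nH]c23)cc(OC)c1OC` carries a 4-methylpiperazin-1-yl group on the phenyl of its amidine; in a functional assay on HT-1080 cells (Homo sapiens) for cytotoxicity, read by MTT assay, with a stated time of 72 h (on this read-out lower numbers stand for stronger inhibition and higher numbers for weaker inhibition), compound 1 gives 3400 nM. Compound 2 `COc1cc(Nc2nc(C(=N)Nc3ccccc3)cc3c(-c4ccccc4)n[nH]c23)cc(OC)c1OC` differs from compound 1 only by hydrogen in place of 4-methylpiperazin-1-yl on an aromatic carbon, and in this assay compound 2 gives 3900 nM. The resulting step is a 1.1-fold higher number from compound 1 to compound 2 (0.06 log units; within the scatter).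

Compound 3 `COc1ccc(Cn2ncc3cc(C(=N)Nc4ccc(N5CCN(C)CC5)cc4)ncc32)cc1` belongs to a second core; the difference between the two cores is not broken down here. In this assay compound 3 gives 5300 nM, which sits close to the values of compound 1 and compound 2.

Compound 4 `COc1ccc(Cn2ncc3cc(C(=N)Nc4ccccc4)ncc32)cc1` is not yet measured. It differs from compound 3 by hydrogen in place of 4-methylpiperazin-1-yl on an aromatic carbon, the same change that separates compound 1 from compound 2, so the change occurs in two pairs among the compounds shown.

For compound 4 the expected step is a 1.1-fold higher number from compound 3 to compound 4 (0.04 log units; within the scatter), resting on the small measured step of a 1.1-fold higher number from compound 1 to compound 2 (0.06 log units; within the scatter) in the other core. Compound 4 is therefore estimated to give 5800 nM in this assay, with a plausible range from 2500 nM to 13000 nM.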

Compound 4, half-maximal inhibitory concentration: 25700 nM
Compound 4: middle estimate off by 4.4-fold (0.65 log units), on the low side; the whole stated range lies below it.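

Removing the 4-methylpiperazin-1-yl group in this assay gives a 4.8-fold higher number from compound 3 to compound 4 (0.69 log units; beyond the scatter), so on the core of compound 3 this change has a measurable effect, unlike on the core of compound 1. The size of the step did not carry over from one core to the other: the same change on two cores in this assay, a 1.1-fold higher number (0.06 log units; within the scatter) from compound 1 to compound 2 and a 4.8-fold higher number (0.69 log units; beyond the scatter) from compound 3 to compound 4, 4.2-fold (0.63 log units) apart, beyond the scatter of two such steps. This shows that, in this series, a step measured on one core is no safe guide to the same change on another, but two pairs cannot show which feature of either core sets the steps apart, and they give no rule for any further core.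

The compounds shown leave open whether the higher number for compound 4 reflects the loss of the whole 4-methylpiperazin-1-yl group or only of its amine, a question that a morpholine or a dimethylamino group in the same place would bear on. They also leave open whether a carboxylic acid there would separate the two cores in the same way.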